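Moving the nitrile on the cyanophenyl group of compound 3

This account rests on a few compounds, and the source may have more. Where it says the series, first, only, none or still open, it means among the compounds named here.

- compound 1 `Cc1cnc(Nc2cccc(C(=O)N3CCCC3)c2)nc1N[C@H]1[C@@H](C(N)=O)[C@@H]2C=C[C@H]1C2`: 100 nM
- compound 2 `NC(=O)[C@@H]1[C@H](Nc2nc(Nc3cccc(C(=O)N4CCCC4)c3)ncc2-c2cncc(F)c2)[C@H]2C=C[C@@H]1C2`: 170 nM
- compound 3 `N#Cc1cccc(-c2cnc(Nc3cccc(C(=O)N4CCCC4)c3)nc2N[C@H]2[C@@H](C(N)=O)[C@@H]3C=C[C@H]2C3)c1`: 280 nM

In a functional assay on THP-1 cells (Homo sapiens) for inhibition, read by ELISA, with stated times of 1 h and 18 h (on this read-out lower numbers stand for stronger inhibition and higher numbers for weaker inhibition), compound 3 gives 280 nM, and the record shows a 2.8-fold higher number from compound 1 to compound 3 (0.45 log units; beyond the scatter). Its nearest neighbour in the numbers is compound 2, with a 1.6-fold higher number from compound 2 to compound 3 (0.22 log units; within the scatter).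

Compound 4 `N#Cc1ccc(-c2cnc(Nc3cccc(C(=O)N4CCCC4)c3)nc2N[C@H]2[C@@H](C(N)=O)[C@@H]3C=C[C@H]2C3)cc1` has the same atoms joined differently: 4-cyanophenyl in place of 3-cyanophenyl on an aromatic carbon. For the measured compounds named here, no measured step moves a nitrile around its ring, so the evidence is indirect. Exchanging one ring group for another stayed small in a 1.6-fold higher number from compound 2 to compound 3 (0.22 log units; within the scatter), and the methyl replacement gave a 1.7-fold higher number from compound 1 to compound 2 (0.23 log units; within the scatter). No step beyond the scatter is therefore expected, in either direction: the expected step is a 1.1-fold lower number from compound 3 to compound 4 (0.05 log units; within the scatter). Compound 4 is estimated at 250 nM, with an expected range of 110 nM to 570 nM.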

Compound 4, half-maximal inhibitory concentration: 190 nM
Compound 4: middle estimate off by 1.3-fold (0.12 log units), on the high side; measured number inside the range.
By their numbers in this assay, from the lowest: compounds 1, 2, 4 and 3 (each within the scatter of the next, the first and the last beyond it).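

In this assay the nitrile can now be compared directly on its ring: 4-cyanophenyl in place of 3-cyanophenyl gives a 1.5-fold lower number from compound 3 to compound 4 (0.17 log units; within the scatter) and so leaves the number within the scatter. Against methyl, 4-cyanophenyl gives a 1.9-fold higher number from compound 1 to compound 4 (0.28 log units; within the scatter) while 3-cyanophenyl gave a 2.8-fold higher number from compound 1 to compound 3 (0.45 log units; beyond the scatter) and the step to the fluoropyridine, a 1.1-fold higher number from compound 2 to compound 4 (0.05 log units; within the scatter) as well, is also small, so this position accepts all three ring groups with little change. Nothing measured here offers an explanation for these numbers.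

Still open, going by these compounds, is whether a carboxylic acid or an aminomethyl group in place of the nitrile would be accepted as well. A saturated ring such as morpholine at this position is equally untested by these compounds.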